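This account rests on a few compounds, and the source may have more. Where it says the series, first, only, none or still open, it means among the compounds named here.

Measured compounds:
- compound 1 `CNC(=O)N1CCCc2ccc(NC(=O)c3cccc(-c4ccccc4)c3)cc21`: 1.39%
- compound 2 `CNC(=O)N1CCCc2ccc(NC(=O)c3cccc(-c4ccn(S(C)(=O)=O)n4)c3)cc21`: 37%

Going by the values given here, in a functional assay on MV4-11 cells (Homo sapiens) for antiproliferative activity, with a stated time of 6 days, tested at 6.25 uM (on this read-out higher numbers stand for a stronger effect at the one concentration tested and lower numbers for a weaker effect), compound 2 stands highest of the two numbers; the only other compound, compound 1, gives 1.39%, a number lower beyond the scatter. Among the compounds with values here, the single measured step, a number 35.6 percentage points higher from compound 1 to compound 2 (beyond the scatter), is large and shows that the 1-(methylsulfonyl)-1H-pyrazol-3-yl group carries a much stronger effect than phenyl at this position.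

Compound 3 `CNC(=O)N1CCCc2ccc(NC(=O)c3cccc(-c4cc[nH]n4)c3)cc21` keeps the core of compound 2 and differs from it in one place: hydrogen in place of methylsulfonyl on an aromatic nitrogen. Within the data shown here, no measured pair shows this change, so the step from compound 1 to compound 2 bears on it only indirectly. That step cannot say whether the stronger effect of compound 2 rests on the pyrazole ring itself or on the methylsulfonyl that sits on it. Removing the methylsulfonyl therefore carries real uncertainty, and some loss toward the value of compound 1 is expected. The expected step is a number 15 percentage points lower from compound 2 to compound 3 (beyond the scatter), a drop of moderate size rather than a full return to the level of compound 1. For compound 3 the estimate in this assay is 22%, with a range from 2% to 48%.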

Compound 3, a percentage reported as inhibition, at one concentration (the size of the read-out at that concentration, not a potency): 89.7%
Compound 3: middle estimate off by 67.7 percentage points, on the low side; measured number above the stated range.
By their numbers in this assay, from the lowest: compound 1; then compound 2; then compound 3.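

Taken off the aromatic nitrogen, the methylsulfonyl turns out not to be what carries the effect at this position: in this assay the change to hydrogen gives a number 52.7 percentage points higher from compound 2 to compound 3 (beyond the scatter). The earlier step from phenyl could not separate the pyrazole ring from the group on it, and the unsubstituted 1H-pyrazol-3-yl now answers that, with a number 88.3 percentage points higher from compound 1 to compound 3 (beyond the scatter), a step larger than the one seen with the substituted ring. Compound 2 therefore reflects only part of what this ring can give here, and no measurement on hand explains why the hydrogen on the ring nitrogen gives so much more than methylsulfonyl.

The compounds shown leave open whether a smaller group on this nitrogen, such as a methyl or an acetyl, would keep the level of compound 3 or fall toward that of compound 2, and whether a longer chain such as an ethyl would behave like methylsulfonyl. They also leave open how the three compounds would compare at other concentrations, as the read-out comes from one concentration and gives the size of the effect there.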